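Swapping a cyanophenyl arm for a dimethoxyphenyl arm

The source may report more compounds than this note shows. Statements on the series, on what has been measured and on what is new or still open speak of the compounds shown alone.

Compound 1 `N#Cc1ccc(/C=C2\CN(S(=O)(=O)c3ccc(F)cc3)C/C(=C\c3ccccc3F)C2=O)cc1` and compound 2 `COc1cc(/C=C2\CN(S(=O)(=O)c3ccc(F)cc3)C/C(=C\c3ccccc3F)C2=O)cc(OC)c1` share one core and differ in a single arm: 3,5-dimethoxyphenyl in place of 4-cyanophenyl on a double-bonded chain carbon bound to a double-bonded ring carbon. In a functional assay on QGY-7703 cells (Homo sapiens) for cytotoxicity, read by MTT assay, with a stated time of 24 h (a higher number here means a weaker inhibitor, a lower number a stronger inhibitor), compound 1 gives 20100 nM, and compound 2 gives 14000 nM, a step of a 1.4-fold lower number from compound 1 to compound 2 (0.16 log units; within the scatter). Compound 3 `COc1cc(/C=C2\CN(S(=O)(=O)c3ccc(NC(C)=O)cc3)C/C(=C\c3ccc(C#N)cc3)C2=O)cc(OC)c1OC` rests on a different core; how its core differs from that of compound 1 is not broken down here. In this assay compound 3 gives 1890 nM, the lowest of the three numbers, and its gaps to compound 2 and to compound 1 both lie beyond the scatter. Compound 4 `COc1cc(/C=C2\CN(S(=O)(=O)c3ccc(NC(C)=O)cc3)C/C(=C\c3cc(OC)c(OC)c(OC)c3)C2=O)cc(OC)c1` has not yet been measured. It differs from compound 3 by 3,5-dimethoxyphenyl in place of 4-cyanophenyl on a double-bonded chain carbon bound to a double-bonded ring carbon, the same change, at the same place, that turns compound 1 into compound 2. Compound 4 is expected to take a step of a 1.4-fold lower number from compound 3 to compound 4 (0.13 log units; within the scatter) in this assay because the matching step a 1.4-fold lower number from compound 1 to compound 2 (0.16 log units; within the scatter) stayed within the scatter. Compound 4 is therefore estimated at 1400 nM, with a likely range from 500 nM to 4000 nM.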

Compound 4, half-maximal inhibitory concentration: 2020 nM
For compound 4 the middle estimate is 1.4-fold (0.16 log units) below the measured one; the measured number falls inside the stated range.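

In this assay, the swap of 4-cyanophenyl for 3,5-dimethoxyphenyl on a double-bonded chain carbon bound to a double-bonded ring carbon gives a 1.1-fold higher number from compound 3 to compound 4 (0.03 log units; within the scatter), and this step agrees with the one seen on the core of compound 1: the same change on two cores in this assay, a 1.4-fold lower number (0.16 log units; within the scatter) from compound 1 to compound 2 and a 1.1-fold higher number (0.03 log units; within the scatter) from compound 3 to compound 4, 1.5-fold (0.19 log units) apart, within the scatter of two such steps

On these two cores, then, the swap carries over as a change too small to read, which shows that the two cores respond alike but gives no shared effect of any definite size. For the compounds shown here, it rests on only two pairs in a single assay, so it does not show that the swap would stay as quiet on a third core, and it offers no explanation for the result.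

The compounds shown leave open whether a different arm at this place, such as a phenyl ring carrying an amine or a carboxylic acid, would move the number. They also leave open which of the several differences between the core of compound 1 and the core of compound 3 matter in this assay.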